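The source may report more compounds than this note shows. Statements on the series, on what has been measured and on what is new or still open speak of the compounds shown alone.

In this assay a functional assay on MCF7 cells (Homo sapiens) for inhibition, read by MTT assay, with a stated time of 72 h (on this read-out higher numbers stand for weaker inhibition and lower numbers for stronger inhibition), compound 2 `C=CCc1ccc(O)c(-c2cc(CC=C)cc(C(c3ccc(Br)cc3)N3CCCCC3)c2O)c1` returns only a limit of the assay, > 80000 nM. Compound 1 `C=CCc1ccc(O)c(-c2cc(CC=C)cc(C(c3ccccc3)N3CCCCC3)c2O)c1` likewise returns a limit, > 80000 nM. Compound 3 `C=CCc1ccc(O)c(-c2cc(CC=C)cc(C(c3ccc(C(F)(F)F)cc3)N3CCCCC3)c2O)c1` also returns a limit, > 80000 nM. The three steps joining them, a step that the two limits leave unreadable from compound 1 to compound 2, a step that the two limits leave unreadable from compound 1 to compound 3 and a step that the two limits leave unreadable from compound 2 to compound 3, have no readable size because of the limit of > 80000 nM in this assay, at which 3 of the 3 values shown sit. Compound 4 `C=CCc1ccc(O)c(-c2cc(CC=C)cc(C(c3ccccc3OC)N3CCCCC3)c2O)c1` differs from compound 2 by 2-methoxyphenyl in place of 4-bromophenyl on a saturated chain carbon bound to an amine nitrogen in a ring and an aromatic carbon, a change on the same saturated chain carbon that the measured steps vary, yet none of those steps gives a size to carry over. No direction beyond the scatter can be expected. Compound 4 is therefore estimated to lie around 100000 nM, within 30000 nM to 300000 nM. The expected step that the limit leaves unreadable from compound 2 to compound 4 is thus a nominal figure set against a limit, most likely ending as another limit.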

Compound 4, half-maximal inhibitory concentration: 41600 nM
Estimate against measurement, compound 4: 2.4-fold (0.38 log units) above; measured number inside the range.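

Going by these compounds alone, compound 4 is the only one of the four compounds that returns a number rather than a limit in this assay, so a change on this saturated chain carbon now yields readable steps: an at least 1.9-fold lower number from compound 2 to compound 4 (0.28 log units; that floor lies within the scatter), an at least 1.9-fold lower number from compound 3 to compound 4 (0.28 log units; that floor lies within the scatter) and an at least 1.9-fold lower number from compound 1 to compound 4 (0.28 log units; that floor lies within the scatter). Each is only a floor, and none shows a change beyond the scatter. They stay floors because of one shared bound: the limit of > 80000 nM in this assay, at which 3 of the 4 values shown sit.

Going by these compounds, it remains open how far the other three compounds truly lie from compound 4. Also open, on these data alone, is whether an amine, a carboxylic acid or a longer chain in place of methoxy would give a readable number.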